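The source may hold more compounds than are shown below. What is called first, only, known or untested is meant among the compounds shown, and "the series" means these compounds.

Measured compounds:
Compound 1 `CCCCOC(=O)Nc1ccc([Se]C#N)cc1` gives 8100 nM in a functional assay on HT-29 cells (Homo sapiens) for cytotoxicity, read by MTT assay, with a stated time of 72 h; on this read-out lower numbers stand for stronger inhibition of growth and higher numbers for weaker inhibition of growth.
Compound 2 `CCCCCCOC(=O)Nc1ccc([Se][Se]c2ccc(NC(=O)OCCCCCC)cc2)cc1` gives 11000 nM in this assay.
Compound 3 `O=C(Nc1ccc([Se][Se]c2ccc(NC(=O)Oc3ccc(F)cc3)cc2)cc1)Oc1ccc(F)cc1` gives 18500 nM in this assay.

Among these three numbers, compound 1 has the lowest. Compound 2 sits close to it, within the usual scatter of repeated measurements, so no order between compound 1 and compound 2 can be read from these figures. Compound 3 stands further off, beyond the scatter, with a higher number than compound 1, that is, weaker inhibition of growth. Compound 2 and compound 3 lie within the scatter of each other.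

The next compound, compound 4 `N#C[Se]c1ccc(NC(=O)Oc2ccccc2)cc1`, differs from compound 1 in one place: phenyl in place of butyl on an oxygen next to a carbonyl group. Going by the values given here, no measured pair shows this change on its own. Compound 2 and compound 3 do carry an alkyl and an aryl carbamate, but they share a different core and a different chain, so they do not supply a step for this change. On that basis the step from compound 1 to compound 4 in this assay is expected to be a 1.2-fold higher number from compound 1 to compound 4 (0.09 log units; within the scatter), not beyond the scatter. Compound 4 is estimated at 10000 nM, with a range from 4000 nM to 25000 nM.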

Compound 4, concentration for 50% growth inhibition: 11700 nM
The estimate for compound 4 lay 1.2-fold (0.07 log units) below the measured number; the range from low to high includes it.
By their numbers in this assay, from the lowest: compounds 1, 2, 4 and 3 (each within the scatter of the next, the first and the last beyond it).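

Going by these compounds alone, on the shared core, the first direct reading of this position in this assay is a 1.4-fold higher number from compound 1 to compound 4 (0.16 log units; within the scatter), so butyl and phenyl on an oxygen next to a carbonyl group cannot be told apart here. The position therefore carries either an open chain or a six-membered aromatic ring of carbon only with no change that can be read from these figures, something compound 2 and compound 3 could not show, as they differ from the other compounds in more than one place. No measured property of either group accompanies this result, and the figures do not say why the two compounds read alike.

On these data alone, whether a pyridine ring, or a butyl chain ending in an amine or a carboxylic acid, would give a step beyond the scatter at this position remains open. As far as these compounds go, it also remains open whether phenyl in place of butyl would read the same way on the core that compound 2 and compound 3 share, since this single step comes from one pair in one assay.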